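A Hydroxyl-Bearing Chain Replaces the Branched Alkyl

A few compounds are considered here, and "the series" means these few. Any claim that something is new, unique, unknown or untested is made for them only; others in the source may bear on it.

Compound 1 `C#CCNc1ncc(-c2cccc(Cl)c2)c(-c2ccccc2)n1` gives 76% in an assay on CHO cells for displacement of a labelled ligand from adenosine receptor A1 (Homo sapiens), read by scintillation counting, with a stated time of 1 h, tested at 1 uM (a lower number here means less inhibition, a higher number more inhibition at the concentration tested (going by the name of the read-out)), whereas compound 2 `CC(C)CCNc1ncc(-c2cccc(Cl)c2)c(-c2ccccc2)n1` gives 39%, the lower of the two numbers. Within the data shown here, the only measured step, a number 37 percentage points lower from compound 1 to compound 2 (beyond the scatter), concerns the same chain and is the sole guide here. Compound 3 `OCCCNc1ncc(-c2cccc(Cl)c2)c(-c2ccccc2)n1` carries hydroxymethyl in place of isopropyl on a saturated chain carbon, two bonds along the chain from a nitrogen on an aromatic ring. Among the measured compounds shown here, no measured step swaps a plain alkyl chain for one bearing a hydroxyl, so the direction is uncertain; a moderate rise toward compound 1 is expected. Compound 3 is therefore estimated at 48%, within 18% to 76%. The expected step is a number 9 percentage points higher from compound 2 to compound 3 (within the scatter).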

Compound 3, a percentage reported as inhibition, at one concentration (the size of the read-out at that concentration, not a potency): > 80%
Compound 3: a limit, no number; the forecaster's own chance of this, stated with the estimate: 0%; middle value at least 32 percentage points away from the limit.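

At this position on the chain, a hydroxyl-bearing group reverses the loss seen with the branched isopentyl chain, the change reading as a number at least 41 percentage points higher from compound 2 to compound 3 (beyond the scatter). Compound 3 stands at a limit of this assay, not at a number: the limit of > 80% in this assay, at which 1 of the 3 values shown sits. The ethynyl group is therefore not needed for a high reading, yet the two chains cannot be ranked, the comparison giving a number at least 4 percentage points higher from compound 1 to compound 3 (that floor lies within the scatter).

Still open, as far as these compounds go, is whether the hydroxyl or the shorter chain carries the rise, which a plain propyl chain would test. From the compounds shown here alone, whether an amine or a carboxylic acid at the chain end would serve as well also remains unknown.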